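This account rests on a few compounds, and the source may have more. Where it says the series, first, only, none or still open, it means among the compounds named here.

Compound 1 `Cc1cc(/C=C/C#N)cc(C)c1Oc1nc(Nc2ccc(N3CCN(S(N)(=O)=O)CC3)cc2)nc2ccsc12` — > 222000 nM
Compound 2 `Cc1cc(/C=C/C#N)cc(C)c1Oc1nc(Nc2ccc(CN3CCN(S(N)(=O)=O)CC3)cc2)nc2sccc12` — > 217000 nM

In an ADME assay on MT4 cells (Homo sapiens) for cytotoxicity, read by MTT assay, with a stated time of 5 days (a lower number here means that less compound is tolerated, a higher number that more compound is tolerated), compound 1 gives > 222000 nM, which is a limit of the assay and not a number. Compound 2 likewise gives only a limit, > 217000 nM. Both values sit at a limit, the limit of > 217000 nM in this assay, at which 1 of the 2 values shown sits, and (the limit of > 222000 nM in this assay, at which 1 of the 2 values shown sits), so compound 1 stands at the ceiling of what this assay reports, with no measurable difference from compound 2. Compound 3 `Cc1cc(/C=C/C#N)cc(C)c1Oc1nc(Nc2ccc(N3CCCC(N)C3)cc2)nc2ccsc12` differs from compound 1 by 3-aminopiperidin-1-yl in place of 4-sulfamoylpiperazin-1-yl on an aromatic carbon. Within the data shown here, with no measured step known, no shift beyond the scatter is expected in either direction. Compound 3 is therefore expected to give 200000 nM, within 50000 nM to 500000 nM. The expected step of an at least 1.1-fold lower number from compound 1 to compound 3 (0.04 log units; that floor lies within the scatter) is essentially none.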

Compound 3, half-maximal cytotoxic concentration: 3820 nM
For compound 3 the middle estimate is 52-fold (1.72 log units) above the measured one, outside the stated range (below it).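

In this assay, the group at this place, on an aromatic carbon para to a large group, proves able to bring the cytotoxicity into measurable range: 3-aminopiperidin-1-yl in place of 4-sulfamoylpiperazin-1-yl gives an at least 58-fold lower number from compound 1 to compound 3 (1.76 log units; beyond the scatter). The true size of this step remains unknown, as compound 1 gives > 222000 nM, which is a limit of the assay and not a number: the limit of > 222000 nM in this assay, at which 1 of the 3 values shown sits.

The compounds shown leave open whether the change follows the amino group, the piperidine ring or the loss of the sulfamoyl group. A plain piperidin-1-yl or a 4-aminopiperidin-1-yl at this place would bear on that question.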